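The source may hold more compounds than are shown below. What is called first, only, known or untested is meant among the compounds shown, and "the series" means these compounds.

Series notes. The shared core, seen in compound 1 `Nc1scc(CN2CCN(c3ccccc3F)CC2)c1C(=O)c1ccc(Cl)cc1`, carries an aryl group on an amine nitrogen in a ring, and that aryl group is the only part varied across the set. In a functional assay on CHO cells with adenosine receptor A1 (Homo sapiens) as the target, read by cAMP accumulation and immunoassay, with a stated time of 6 min, tested at 0.01 uM (a higher number here means a weaker effect of the compound at the concentration tested, a lower number a stronger effect), compound 1 gives 2.1%. Compound 2 `Nc1scc(CN2CCN(c3ccc(F)cc3F)CC2)c1C(=O)c1ccc(Cl)cc1` gives 0% in this assay, and compound 3 `Nc1scc(CN2CCN(c3ccc(F)c(Cl)c3)CC2)c1C(=O)c1ccc(Cl)cc1` gives 4.2%. Compound 3 thus holds the highest of the three numbers, yet every step among the measured compounds stays within the scatter: a number 2.1 percentage points lower from compound 1 to compound 2 (within the scatter), a number 2.1 percentage points higher from compound 1 to compound 3 (within the scatter) and a number 4.2 percentage points higher from compound 2 to compound 3 (within the scatter). Compound 4 `Nc1scc(CN2CCN(c3ccc(Cl)c(Cl)c3)CC2)c1C(=O)c1ccc(Cl)cc1` has not yet been measured; it differs from compound 3 by chloro in place of fluoro on an aromatic carbon. Among the compounds with values here, the steps that bear on this change are the three just given, all of them within the scatter, and together they show that swapping halogens on this aryl group has not taken the read-out beyond the scatter at the concentration tested. For compound 4 the expected step is therefore none beyond the scatter, a number 0.2 percentage points lower from compound 3 to compound 4 (within the scatter). Compound 4 is estimated at 4% in this assay, with a range from 0% to 12%.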

Compound 4, a percentage reported as activity, at one concentration (the size of the read-out at that concentration, not a potency): -1.2%
Compound 4: middle estimate off by 5.2 percentage points, on the high side; measured number below the stated range.
By their numbers in this assay, from the lowest: compounds 4, 2, 1 and 3 (each within the scatter of the next).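

In this assay the change from 3-chloro-4-fluorophenyl to 3,4-dichlorophenyl, with chloro in place of fluoro on an aromatic carbon ortho to a chloro group and para to a large group, gives a number 5.4 percentage points lower from compound 3 to compound 4 (within the scatter) and so does not separate these two aryl groups at the concentration tested. The same holds against the two fluorinated aryl groups without chloro, with a number 1.2 percentage points lower from compound 2 to compound 4 (within the scatter) and a number 3.3 percentage points lower from compound 1 to compound 4 (within the scatter) in the same assay, so the second chloro adds a fourth halogen pattern that cannot be told apart from the other three. Nothing shown here gives a reason for where these read-outs fall.

The compounds shown leave open whether a group other than a halogen on this aryl ring, such as methoxy, nitrile or an amine, or a plain phenyl group with no halogen at all, would take the read-out beyond the scatter. Also open, from the compounds shown here alone, is how the four compounds compare in potency, as a read-out at one concentration gives only the size of the effect at that concentration.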